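A few compounds are considered here, and "the series" means these few. Any claim that something is new, unique, unknown or untested is made for them only; others in the source may bear on it.

Among the compounds with values here, compound 1 `CCSc1nc(N)c2nc(O)n(Cc3ccccc3)c2n1` is the only compound here with a plain number in a functional assay (spleen, spleen) for activation, with Mus musculus as the target (a higher number here means that more compound is needed for the effect, a lower number that less compound is needed), where compound 1 gives 0.1 uM. Compound 2 `COc1nc2c(N)ncnc2n1Cc1ccccc1` reaches no number in this assay: compound 2 returns only the limit > 10 uM. Compound 3 `CCOc1nc(N)c2nc(O)n(Cc3ccccc3)c2n1` is not yet measured; it differs from compound 1 in one place: ethoxy in place of ethylsulfanyl on an aromatic carbon. Within the data shown here, no measured pair shows this exchange, so nothing calibrates its size. The expected step is small, within the usual scatter or at most a slight loss, as given by a 2.0-fold higher number from compound 1 to compound 3 (0.30 log units; within the scatter). Compound 3 is estimated at 0.2 uM in this assay, with a range from 0.05 uM to 1 uM.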

Compound 3, minimum effective concentration: 0.1 uM
Compound 3: the middle estimate sits 2.0-fold (0.30 log units) above what was measured; the range from low to high includes it.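

Within this assay the exchange of ethylsulfanyl for ethoxy on the aromatic carbon between two ring nitrogen atoms gives no change at the digits printed from compound 1 to compound 3 (within the scatter) and is the only measured exchange at this position. It shows that, on the core of compound 1, oxygen can stand in place of sulfur in this chain without a step beyond the scatter. Nothing shown offers a cause for this result. Still open, as far as these compounds go, is how a longer chain such as butoxy, or an amine such as ethylamino, would read at this position.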